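This account rests on a few compounds, and the source may have more. Where it says the series, first, only, none or still open, it means among the compounds named here.

Working notes on the shared core of compound 1 `Nc1ccccc1NC(=O)CCCCCCc1nc(-c2ccccc2)no1`, in which only the aryl group on the five-membered ring varies. In a functional assay on NCI-H661 cells (Homo sapiens) for antiproliferative activity, read by MTT assay, with a stated time of 72 h (a higher number here means a weaker inhibitor, a lower number a stronger inhibitor), compound 1 gives 960 nM. Compound 2 `Nc1ccccc1NC(=O)CCCCCCc1nc(-c2ccc(C(F)(F)F)cc2)no1` gives 29800 nM. Compound 3 `Nc1ccccc1NC(=O)CCCCCCc1nc(-c2ccccc2Cl)no1` gives 8310 nM, the second highest of the three numbers; an 8.7-fold higher number from compound 1 to compound 3 (0.94 log units; beyond the scatter) and a 3.6-fold lower number from compound 2 to compound 3 (0.55 log units; beyond the scatter) place it between the other two. The unmeasured compound 4 `Nc1ccccc1NC(=O)CCCCCCc1nc(-c2ccc([N+](=O)[O-])cc2)no1` differs from compound 3 by 4-nitrophenyl in place of 2-chlorophenyl on an aromatic carbon. The step bearing most closely is a 31-fold higher number from compound 1 to compound 2 (1.49 log units; beyond the scatter), where the phenyl became 4-(trifluoromethyl)phenyl, the nearest analogue of 4-nitrophenyl; an 8.7-fold higher number from compound 1 to compound 3 (0.94 log units; beyond the scatter) also shows a substituted phenyl raising the number. A higher number is therefore expected, roughly a 2.4-fold higher number from compound 3 to compound 4 (0.38 log units; beyond the scatter). Compound 4 is estimated at 20000 nM, range 5000 nM to 80000 nM.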

Compound 4, half-maximal inhibitory concentration: > 100000 nM
Compound 4 ended at the assay's limit; the forecaster's own chance of this, stated with the estimate: 10%; middle value at least 5.0-fold (0.69 log units) from the limit.
By their numbers in this assay, from the lowest: compound 1; then compound 3; then compound 2. At a limit, above all of these: compound 4.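

Compound 4 gives a limit, not a number: the limit of > 100000 nM in this assay, at which 1 of the 4 values shown sits. Among these compounds, the aryl position between two ring nitrogen atoms therefore tolerates less than the earlier compounds showed, with 4-nitrophenyl giving an at least 100-fold higher number from compound 1 to compound 4 (2.01 log units; beyond the scatter) and an at least 12-fold higher number from compound 3 to compound 4 (1.08 log units; beyond the scatter). The choice of group on the phenyl still matters beyond 4-(trifluoromethyl)phenyl, as nitro in place of trifluoromethyl gives an at least 3.3-fold higher number from compound 2 to compound 4 (0.52 log units; beyond the scatter). All three substituted phenyls give higher numbers than compound 1, and none goes against this. Open, as far as these compounds go, is whether an amine or a methoxy group on the phenyl would give a lower number than compound 1.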